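A few compounds are considered here, and "the series" means these few. Any claim that something is new, unique, unknown or untested is made for them only; others in the source may bear on it.

Measured compounds:
compound 1 `COc1cc(O)c([C@H](/C=C/C[C@@H](O)CCc2ccc(O)cc2)c2ccc(O)cc2)c(O)c1C(=O)/C=C/c1ccc(O)cc1` — 84000 nM
compound 2 `COc1cc(O)c([C@H](/C=C/C[C@H](CCc2ccc(O)cc2)OO)c2ccc(O)cc2)c(O)c1C(=O)/C=C/c1ccc(O)cc1` — 49000 nM

In a functional assay on J774.1 cells (Mus musculus) for inhibition, read by Griess assay, with a stated time of 48 h (on this read-out lower numbers stand for stronger inhibition and higher numbers for weaker inhibition), compound 1 gives 84000 nM, while compound 2 gives 49000 nM. Compound 1 stands at the top of these two numbers, but the step of a 1.7-fold lower number from compound 1 to compound 2 (0.23 log units; within the scatter) falls within the scatter, so the two compounds cannot be told apart on this read-out.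

Compound 3 `COc1cc(O)c([C@@H](/C=C/C[C@@H](O)CCc2ccc(O)cc2)c2ccc(O)cc2)c(O)c1C(=O)/C=C/c1ccc(O)cc1` differs from compound 1 as follows: the two compounds have the same atoms and bonds and differ only in configuration as drawn: 1 of 4 stereo elements differ; a stereocentre at a saturated chain carbon is drawn R in compound 1 and S in compound 3. Among the compounds with values here, no measured step involves a change of configuration; the single recorded step, from compound 1 to compound 2, concerns a hydroxy in place of hydrogen and itself stays within the scatter. Nothing in these data therefore points to a shift in either direction for compound 3, and the expected step of no change at the digits printed from compound 1 to compound 3 (within the scatter) is one of no change beyond the scatter. Compound 3 is accordingly estimated at 84000 nM, with a range from 35000 nM to 200000 nM.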

Compound 3, half-maximal inhibitory concentration: 39000 nM
Estimate against measurement, compound 3: 2.2-fold (0.33 log units) above; measured number inside the range.
By their numbers in this assay, from the lowest: compounds 3, 2 and 1 (each within the scatter of the next, the first and the last beyond it).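

In this assay, the change of configuration alone gives a 2.2-fold lower number from compound 1 to compound 3 (0.33 log units; beyond the scatter), a modest step but the first here to clear the scatter. Within the data shown here, the only earlier step, a 1.7-fold lower number from compound 1 to compound 2 (0.23 log units; within the scatter), stayed within the scatter and so gave no sign that anything in these compounds could move the number. The drawn configuration at this saturated chain carbon therefore matters to this read-out, and the shift can be assigned to that stereocentre alone because nothing else separates the pair: the fact that compounds 1 and 3 differ only in the configuration as drawn

The compounds shown leave open whether the other stereo elements of the core of compound 1 affect the number to a similar extent. They also leave open what an amine or a longer chain would do to it in either configuration.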